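Swapping the aromatic cap on a shared core

The source may report more compounds than this note shows. Statements on the series, on what has been measured and on what is new or still open speak of the compounds shown alone.

Of the compounds shown here, three built on one shared core have been tested in a functional assay on A2780cisR cells (Homo sapiens) for cytotoxicity, read by MTT assay, with a stated time of 72 h; a higher number here means a weaker inhibitor, a lower number a stronger inhibitor. Compound 1 `CN(C)c1ccc(C(=O)N(CCCCCC(=O)NO)CC(=O)NC2CCCCC2)cc1` gives 3310 nM in this assay. Compound 2 `CCCCNC(=O)CN(CCCCCC(=O)NO)C(=O)c1ccc(N(C)C)cc1`, which carries butyl in place of cyclohexyl on an amide-type nitrogen, gives 3190 nM, and the step of a 1.0-fold lower number from compound 1 to compound 2 (0.02 log units; within the scatter) is small. Compound 3 `O=C(CCCCCN(CC(=O)NC1CCCCC1)C(=O)c1cccc2ccccc12)NO`, which carries naphthalen-1-yl in place of 4-(dimethylamino)phenyl on a carbonyl carbon, gives 4120 nM; the step of a 1.2-fold higher number from compound 1 to compound 3 (0.10 log units; within the scatter) is likewise within the scatter. Compound 3 thus has the highest of the three numbers, but neither neighbour is separated from it beyond the scatter, so no order among the three can be claimed.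

Compound 4 `O=C(CCCCCN(CC(=O)NC1CCCCC1)C(=O)c1ccccc1)NO` differs from compound 3 at the same carbonyl carbon: phenyl in place of naphthalen-1-yl on a carbonyl carbon. For the measured compounds named here, the one measured step that bears on this place is the one from compound 1 to compound 3, which exchanged one aromatic cap for another and changed nothing beyond the scatter. On that basis the step of a 1.1-fold lower number from compound 3 to compound 4 (0.04 log units; within the scatter) is expected to stay within the scatter as well, in no clear direction. Compound 4 is therefore estimated to give 3800 nM, with a range from 1900 nM to 7600 nM.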

Compound 4, half-maximal inhibitory concentration: 8210 nM
For compound 4 the middle estimate is 2.2-fold (0.33 log units) below the measured one; the whole stated range lies below it.
By their numbers in this assay, from the lowest: compounds 2, 1, 3 and 4 (each within the scatter of the next, the first and the last beyond it).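

Within this assay, the change of hydrogen in place of dimethylamino on an aromatic carbon gives a 2.5-fold higher number from compound 1 to compound 4 (0.39 log units; beyond the scatter), the first step in this small set to leave the scatter, though only modestly. The cap on the carbonyl carbon can therefore influence the number in this cell assay, and here the difference lies in a single substituent on the phenyl ring rather than in a swap of one whole aromatic cap for another. By contrast, phenyl in place of naphthalen-1-yl gives a 2.0-fold higher number from compound 3 to compound 4 (0.30 log units; within the scatter), so these two caps cannot be told apart, even though the second ring accounts for the larger of the two caps; nothing shown explains the effect of losing dimethylamino.

The compounds shown leave open whether a smaller amine, a methoxy group or a carboxylic acid on the same aromatic carbon would give a number nearer that of compound 1 or that of compound 4. As far as these compounds go, it also remains open whether the loss of dimethylamino would have a similar effect with butyl in place of cyclohexyl on the amide-type nitrogen.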